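Fluorine pattern on the thiazolidinone aryl group

A few compounds are considered here, and "the series" means these few. Any claim that something is new, unique, unknown or untested is made for them only; others in the source may bear on it.

Compound 1 `CCNC(=O)N1CCC(Oc2cc3nccc(Oc4ccc(NC(=O)NN5C(=O)CSC5c5ccc(F)cc5)cc4)c3cc2OC)CC1`: 2250 nM
Compound 2 `COc1cc2c(Oc3ccc(NC(=O)NN4C(=O)CSC4c4ccc(F)cc4)cc3)ccnc2cc1OC1CCN(C(=O)NC2CCCCC2)CC1`: 3420 nM
Compound 3 `COc1cc2c(Oc3ccc(NC(=O)NN4C(=O)CSC4c4ccc(F)c(F)c4)cc3)ccnc2cc1OC1CCN(C(=O)NC(C)C)CC1`: 1060 nM

Of the compounds shown here, three sharing one core have been measured in a functional assay on HT-29 cells (Homo sapiens) for inhibition, read by MTT assay; on this read-out higher numbers stand for weaker inhibition and lower numbers for stronger inhibition. Compound 3 gives the lowest number of the three in this assay, at 1060 nM; compound 1 stands higher at 2250 nM, and compound 2 higher still at 3420 nM. Among the measured compounds shown here, the only single-point step among the measured compounds, a 1.5-fold higher number from compound 1 to compound 2 (0.18 log units; within the scatter), concerns the substituent on an amide-type nitrogen and lies within the scatter.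

Compound 4 `COc1cc2c(Oc3ccc(NC(=O)NN4C(=O)CSC4c4c(F)cc(F)cc4F)cc3)ccnc2cc1OC1CCN(C(=O)NC(C)C)CC1` is not yet measured. It differs from compound 3 in one place: 2,4,6-trifluorophenyl in place of 3,4-difluorophenyl on a saturated ring carbon. For the measured compounds named here, no measured step touches this aryl group, so nothing among the three compounds bears directly on the change; the one step known, at the amide nitrogen, was small. On that basis the step from compound 3 to compound 4 is expected to be no larger than the scatter, a 1.2-fold higher number from compound 3 to compound 4 (0.09 log units; within the scatter), in either direction. Compound 4 is therefore estimated at 1300 nM in this assay, with a range from 450 nM to 3800 nM.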

Compound 4, half-maximal inhibitory concentration: 910 nM
Estimate against measurement, compound 4: 1.4-fold (0.15 log units) above; low and high end bracket the measured number.
By their numbers in this assay, from the lowest: compounds 4 and 3 (each within the scatter of the next); then compounds 1 and 2 (each within the scatter of the next).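

The aryl group on the saturated ring carbon now has its first direct comparison: in this assay, placing 2,4,6-trifluorophenyl where 3,4-difluorophenyl stood gives a 1.2-fold lower number from compound 3 to compound 4 (0.07 log units; within the scatter). For this pair, with the rest of the molecule unchanged, one more fluorine and a different fluorine pattern leave the two numbers indistinguishable in this assay. No evidence is available on why the two fluorine patterns read alike.

The compounds shown carry only fluorinated phenyl groups at this position, so it remains open how an unsubstituted phenyl, a methoxyphenyl or a pyridine ring would read here. Also open, on these data alone, is whether the two fluorine patterns would still read alike with ethyl or cyclohexyl on the amide-type nitrogen in place of the group carried by compound 3 and compound 4.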